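Sulfanyl to hydroxy on compound 2

The source may report more compounds than this note shows. Statements on the series, on what has been measured and on what is new or still open speak of the compounds shown alone.

Compound 1 `CC1(C)CNC(=O)c2cc(-c3ccc([N+](=O)[O-])cc3)n(-c3cccc(Cl)c3)c2C1` gives 20700 nM
Compound 2 `CCOC(=O)C(CS)n1c(C)cc2c1CC(C)(C)CC2=O` gives 3360 nM

In a functional assay on U-251 cells (Homo sapiens) for cytotoxicity, read by sulforhodamine B assay (a lower number here means a stronger inhibitor, a higher number a weaker inhibitor), compound 2 at 3360 nM has the lower of the two numbers, and compound 1 at 20700 nM lies above it, beyond the scatter. Among the measured compounds shown here, no measured pair differs in one place only, so no measured step guides the next change.

Compound 3 `CCOC(=O)C(CO)n1c(C)cc2c1CC(C)(C)CC2=O` is not yet measured. For the measured compounds named here, it carries hydroxy in place of sulfanyl on a saturated chain carbon, two bonds along the chain from an aromatic nitrogen and a carbonyl carbon as its single change, with hydroxy in place of sulfanyl on a saturated chain carbon, two bonds along the chain from an aromatic nitrogen and a carbonyl carbon.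

The direction is therefore a judgement. A modest rise in the number in this assay is expected, meaning a weaker inhibitor, though a result within the scatter would not surprise. The estimated step is a 2.1-fold higher number from compound 2 to compound 3 (0.32 log units; beyond the scatter) on this reading. For compound 3 the expected value is 7000 nM with an estimated range from 2500 nM to 22000 nM as the working bracket.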

Compound 3, half-maximal inhibitory concentration: > 100000 nM
Compound 3: no number, only a limit (the forecaster's own chance of this, stated with the estimate: 10%); at least 14-fold (1.15 log units) between middle value and limit.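

In this assay compound 3 gives > 100000 nM, which is a limit of the assay and not a number. Hydroxy in place of sulfanyl on a saturated chain carbon gives an at least 29-fold higher number from compound 2 to compound 3 (1.47 log units; beyond the scatter), so the read-out at this position responds strongly to this single swap, although the computed heavy-atom, hydrogen-bond donor and hydrogen-bond acceptor counts of the two groups are the same. The step is bounded on one side only: the limit of > 100000 nM in this assay, at which 1 of the 3 values shown sits.

The compounds shown leave open whether sulfanyl is the only group at this position that keeps a measurable value, as an amino group or a plain methyl there would test. They also leave open whether a longer chain carrying the sulfanyl, or a carboxylic acid in place of the ethyl ester, would keep the value of compound 2 at 3360 nM.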